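Pyrazolyl Replaces Methyl on the Amide Nitrogen of Compound 2

This account rests on a few compounds, and the source may have more. Where it says the series, first, only, none or still open, it means among the compounds named here.

Compound 2 `Cc1ccc(OCC(=O)N(C)Cc2cccs2)cc1` carries a methyl and a thiophen-2-ylmethyl on its amide nitrogen. Among the compounds with values here, in an assay on HEK293 cells for agonist activity at transient receptor potential cation channel subfamily M member 8 (Homo sapiens), read by fluorescence and calcium flux, with a stated time of 15 min (on this read-out higher numbers stand for an effect only at larger amounts of compound and lower numbers for an effect already at smaller amounts), compound 2 gives 400 nM, the second highest of the three numbers measured so far. Its nearest neighbour on that scale is compound 1 `CCN(Cc1cncs1)C(=O)COc1ccc(C)cc1`, which in this assay gives 1100 nM, a number higher than that of compound 2 by a margin beyond the usual scatter. Far below both stands compound 3 `COc1ccc2oc(C(=O)N(Cc3cccs3)c3ccn[nH]3)cc2c1`, built on a different core and carrying a pyrazolyl instead of an alkyl on its amide nitrogen; in this assay compound 3 gives 1.1 nM.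

Compound 4 `Cc1ccc(OCC(=O)N(Cc2cccs2)c2c[nH]nc2C)cc1` has not yet been measured. It differs from compound 2 in one place: 3-methyl-1H-pyrazol-4-yl in place of methyl on an amide-type nitrogen. Because compound 3 reaches 1.1 nM with an aromatic ring on its amide nitrogen, a step downward beyond the scatter is expected for compound 4, although the core of compound 3 also differs, so the size is uncertain; the expected step is a 13-fold lower number from compound 2 to compound 4 (1.12 log units; beyond the scatter). Compound 4 is therefore estimated to give 30 nM in this assay, within a range from 5 nM to 200 nM.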

Compound 4, half-maximal effective concentration: 0.4 nM
For compound 4 the middle estimate is 75-fold (1.88 log units) above the measured one, outside the stated range (below it).
By their numbers in this assay, from the lowest: compound 4; then compound 3; then compound 2; then compound 1.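

In this assay the exchange of methyl for 3-methyl-1H-pyrazol-4-yl on the amide-type nitrogen gives a 1000-fold lower number from compound 2 to compound 4 (3.00 log units; beyond the scatter), a large step beyond the usual scatter. Within the data shown here, no two earlier compounds differed in one place only, so this is the first step that can be read at this position, and it shows that the number falls steeply with the rest of compound 2 unchanged. Nothing measured here explains why the step is so large.

On these data alone, it remains open whether the step belongs to the pyrazole ring as such or to its methyl, which an unsubstituted pyrazol-4-yl or a phenyl on this nitrogen would help to separate. Also open, as far as these compounds go, is how far the result depends on the thiophen-2-ylmethyl on the same nitrogen, which a benzyl in its place would test.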